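The source may hold more compounds than are shown below. What is called first, only, known or untested is meant among the compounds shown, and "the series" means these compounds.

Going by the values given here, compound 1, `O=C(CCCCCCc1ccccc1)c1nc(Br)co1`, is one of three compounds measured in an assay on isolated protein for inhibition of Fatty-acid amide hydrolase 1 (Rattus norvegicus) (a higher number here means a weaker inhibitor, a lower number a stronger inhibitor), where compound 1 gives 3 nM. This places it second highest of the three numbers. Its nearest neighbour is compound 2, `O=C(CCCCCCc1ccccc1)c1nc(Cl)co1`, which in this assay gives 4 nM, a step of a 1.3-fold higher number from compound 1 to compound 2 (0.12 log units; within the scatter). Further off is compound 3, `CNC(=O)c1coc(C(=O)CCCCCCc2ccccc2)n1`, which in this assay gives 1.8 nM, a step of a 1.7-fold lower number from compound 1 to compound 3 (0.22 log units; within the scatter). The step between the other two, a 2.2-fold lower number from compound 2 to compound 3 (0.35 log units; beyond the scatter), is the only one that goes beyond the scatter.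

Compound 4, `O=C(CCCCCCc1ccccc1)c1nc(C(F)(F)F)co1`, differs from compound 1 in one place: trifluoromethyl in place of bromo on an aromatic carbon. Among the compounds with values here, the two measured steps that start from compound 1 both stay within the scatter, and both involve the same position on the shared core, so the nearest precedent suggests little movement. Neither step, however, puts a trifluoromethyl at that position. The step from compound 1 to compound 4 is therefore expected to be a 1.3-fold higher number from compound 1 to compound 4 (0.12 log units; within the scatter). Compound 4 is estimated to give 4 nM, with a likely range from 1.5 nM to 12 nM.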

Compound 4, inhibition constant: 3.7 nM
Estimate against measurement, compound 4: 1.1-fold (0.03 log units) above, within the range that was stated.
By their numbers in this assay, from the lowest: compounds 3, 1, 4 and 2 (each within the scatter of the next, the first and the last beyond it).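

In this assay, trifluoromethyl brings four heavy atoms where bromo has one, yet the move shows as a 1.2-fold higher number from compound 1 to compound 4 (0.09 log units; within the scatter) and, against chloro, as a 1.1-fold lower number from compound 2 to compound 4 (0.03 log units; within the scatter) so this position accepts the larger group with no change that can be told from scatter. Going by these compounds alone, replacing methylcarbamoyl gives the only new step that clears the scatter, a 2.1-fold higher number from compound 3 to compound 4 (0.31 log units; beyond the scatter) and that step is modest, so the four groups seen here span only a narrow band at this position. No measured property of these groups accompanies the numbers, so nothing here accounts for that narrow band.

On these data alone, whether a carboxylic acid, an amine or a plain hydrogen at this position would stay within the same band remains open. So does whether trifluoromethyl would behave alike with a shorter chain on the carbonyl.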